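The source may hold more compounds than are shown below. What is called first, only, known or untested is meant among the compounds shown, and "the series" means these compounds.

Three compounds have been measured in a physicochemical assay for lipophilicity; on this read-out higher numbers stand for higher lipophilicity and lower numbers for lower lipophilicity:

Compound 1 (`C/C=C/C=C/C(=O)N(C)C`): 1.1
Compound 2 (`C/C=C/C=C/C(=O)NN`): 0.59
Compound 3 (`C/C=C/C=C/C(=O)OCC`): 1.84

Compound 3 stands highest of the three, at 1.84. Two measured steps lead to it: a number 0.74 log units higher from compound 1 to compound 3 (beyond the scatter) and a number 1.25 log units higher from compound 2 to compound 3 (beyond the scatter). The third step is a number 0.51 log units lower from compound 1 to compound 2 (beyond the scatter).

Compound 4 (`C/C=C/C=C/C(=O)OC(C)CC`) has not yet been measured. It keeps the shared core and differs from compound 3 in one place: ethyl in place of hydrogen on a saturated chain carbon bound to an oxygen next to a carbonyl group and a saturated chain carbon. Cut one bond further out, the same difference reads ethyl to sec-butyl.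

Among the compounds with values here, no measured step makes this exact change. All three exchange the whole group on the carbonyl carbon, so they bear on it only indirectly, showing how far the number can move when that part of the structure changes. The added ethyl brings carbon only, with no hydrogen-bond donors or acceptors. An upward move in this assay is therefore expected, similar in size to a number 0.74 log units higher from compound 1 to compound 3 (beyond the scatter) and smaller than a number 1.25 log units higher from compound 2 to compound 3 (beyond the scatter). The expected step is a number 0.86 log units higher from compound 3 to compound 4 (beyond the scatter). For compound 4 the estimated value is 2.7, with an expected range from 2.3 to 3.1.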

Compound 4, partition coefficient: 2.72
For compound 4 the middle estimate is 0.02 log units below the measured one; the measured number falls inside the stated range.
By their numbers in this assay, from the lowest: compound 2; then compound 1; then compound 3; then compound 4.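

In this assay, within the data shown here, the earlier steps all exchanged the whole group on the carbonyl carbon, whereas this result is the first to read a change further out, with the oxygen kept in place: ethyl to sec-butyl gives a number 0.88 log units higher from compound 3 to compound 4 (beyond the scatter). The entering ethyl holds carbon only, with 0 hydrogen-bond donors and 0 hydrogen-bond acceptors, yet this step is classed as modest, as is the whole-group exchange that gives a number 0.74 log units higher from compound 1 to compound 3 (beyond the scatter), so this saturated chain carbon is a place where the number still moves well beyond the scatter. Nothing among the data accounts for the size of this step.

The compounds shown leave open whether the number keeps rising with a longer chain at this place, or whether an amine or a carboxylic acid on the same saturated chain carbon would reverse the step. A straight butyl chain or an isopropyl group in the same place would be needed to separate the branching in sec-butyl from the added carbon alone.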